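The compounds below may be only part of what the source reports. "The series", "measured", "known", "first", "only" and "open" are said of these compounds alone.

Three compounds share one core, a carbonyl-linked unsaturated acid attached to a substituted benzene, and differ only in the alkyl groups on the aromatic ring. Compound 1 `CC(C)c1ccc(C(C)C)c(C(=O)/C=C/C(=O)O)c1` carries two isopropyl groups, compound 2 `CCc1cc(CC)c(C(=O)/C=C/C(=O)O)c(CC)c1` carries three ethyl groups, and compound 3 `CCc1ccc(C(=O)/C=C/C(=O)O)cc1` carries a single ethyl group. In a functional assay on HeLa cells (Homo sapiens) for inhibition, read by MTT assay, with a stated time of 72 h (a higher number here means a weaker inhibitor, a lower number a stronger inhibitor), compound 1 gives 4750 nM, the lowest of the three numbers. Compound 2 gives 6530 nM in this assay, a value within the usual scatter of that of compound 1, so the two cannot be ranked. Compound 3, in this assay, gives 27800 nM, a number well beyond the scatter above compound 1.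

Compound 4 `CCc1ccc(C(C)C)cc1C(=O)/C=C/C(=O)O` has not yet been measured. It differs from compound 1 in one place: hydrogen in place of methyl on a saturated chain carbon bound to an aromatic carbon and a saturated chain carbon. Cut one bond further out, the change reads isopropyl to ethyl. Since compound 2, with three ethyl groups, gives 6530 nM close to compound 1, the loss of a single methyl is expected to shift the number only a little, if at all, and the step from compound 1 to compound 4 is expected to be a 1.4-fold higher number from compound 1 to compound 4 (0.14 log units; within the scatter), within the scatter. Compound 4 is therefore estimated at 6500 nM, with a range from 3000 nM to 14000 nM.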

Compound 4, half-maximal inhibitory concentration: 4890 nM
Beside the measured number, compound 4's estimate is 1.3-fold (0.12 log units) above it, within the range that was stated.
By their numbers in this assay, from the lowest: compounds 1, 4 and 2 (each within the scatter of the next); then compound 3.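

In this assay, among the compounds shown here, the change from isopropyl to ethyl gives a 1.0-fold higher number from compound 1 to compound 4 (0.01 log units; within the scatter), the first step in this set that isolates a single place on the shared core. Removing one methyl from this saturated chain carbon therefore leaves the number within the scatter, so isopropyl and ethyl cannot be told apart here. No measurement at hand bears on why this change is so quiet.

The compounds shown leave open whether a longer chain, a tert-butyl group or an amine at this place would also leave the number within the scatter. They also leave open whether the isopropyl group that remains in compound 4 could give way to ethyl with as small a step.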